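The source may hold more compounds than are shown below. What is called first, only, known or untested is meant among the compounds shown, and "the series" means these compounds.

Of the compounds shown here, three sharing one core have been tested in a functional assay on the whole organism for inhibition, with Rattus norvegicus as the target, read by paw edema, with stated times of 30 min and 1 h, at a dose of 0.28 mmol/kg by the oral route; on this read-out higher numbers stand for more inhibition at the one dose given (going by the name of the read-out) and lower numbers for less inhibition. Compound 1 `CCNC(=O)c1nc(-c2cc(OC)c(OC)c(OC)c2)n(-c2ccc(OC)cc2)n1` carries an ethyl group on the amide nitrogen and gives 60%. Compound 2 `COc1ccc(-n2nc(C(=O)Nc3ccccc3C)nc2-c2cc(OC)c(OC)c(OC)c2)cc1` gives 19%, and compound 3 `COc1ccc(-n2nc(C(=O)Nc3ccc(C(F)(F)F)cc3)nc2-c2cc(OC)c(OC)c(OC)c2)cc1` gives 48%. On these numbers compound 3 stands second highest of three: it lies a number 12 percentage points lower from compound 1 to compound 3 (beyond the scatter) and a number 29 percentage points higher from compound 2 to compound 3 (beyond the scatter).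

Compound 4 `COc1ccc(-n2nc(C(=O)Nc3ccc(O)cc3)nc2-c2cc(OC)c(OC)c(OC)c2)cc1` differs from compound 3 only in the group on the six-membered ring of the amide part: hydroxy in place of trifluoromethyl on an aromatic carbon. Among the compounds with values here, no measured step changes a group on that ring; every measured step swaps the whole group on the amide nitrogen. The nearest guide is the swap of one six-membered ring for another, which moved the number by a number 29 percentage points higher from compound 2 to compound 3 (beyond the scatter), and the swap of ethyl for a ring, which moved it by a number 41 percentage points lower from compound 1 to compound 2 (beyond the scatter) and a number 12 percentage points lower from compound 1 to compound 3 (beyond the scatter). These show that the group on the amide nitrogen matters, but they give no direction for a hydroxy in place of trifluoromethyl. The expected step in this assay is therefore a number 6 percentage points lower from compound 3 to compound 4 (within the scatter), small and uncertain. Compound 4 is estimated at 42%, within a range of 22% to 60%.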

Compound 4, a percentage reported as inhibition, in the whole organism at one dose (the size of the read-out at that dose, not a potency): 36%
Beside the measured number, compound 4's estimate is 6 percentage points above it; the range from low to high includes it.
By their numbers in this assay, from the lowest: compound 2; then compound 4; then compound 3; then compound 1.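

Putting hydroxy in place of trifluoromethyl on an aromatic carbon para to a large group gives a number 12 percentage points lower from compound 3 to compound 4 (beyond the scatter) in this assay. Within the data shown here, this is the first step that alters only a group on this six-membered ring while leaving the ring itself in place, and it shows that this one position can move the number beyond the scatter. The hydroxy compound still compares well with the 2-methylphenyl amide, with a number 17 percentage points higher from compound 2 to compound 4 (beyond the scatter), but it does not match the ethyl amide, with a number 24 percentage points lower from compound 1 to compound 4 (beyond the scatter), so compound 1 keeps the highest number of the four. Nothing measured here bears on what lies behind these steps.

The compounds shown hold only trifluoromethyl and hydroxy at this place on the ring, so it remains open how an amine or a carboxylic acid there would compare, and whether any group at this place could bring a ring-bearing amide level with compound 1. From the compounds shown here alone, it also remains open how a longer chain, such as propyl, would compare with ethyl on the amide nitrogen.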